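Loss of a Methyl Group Compared on Two Related Cores

The source may hold more compounds than are shown below. What is called first, only, known or untested is meant among the compounds shown, and "the series" means these compounds.

Compound 1 `Cc1cn(-c2csc(Nc3ccc(Br)cc3)n2)c(C)n1` and compound 3 `COc1ccc(Nc2nc(-n3c(C)nc4ccccc43)cs2)cc1` each carry a methyl on an aromatic carbon of a five-membered aromatic ring with 2 nitrogen; how their two cores differ beyond that is not broken down here. In a functional assay on RKO cells (Homo sapiens) for cytotoxicity, read by resazurin assay, with a stated time of 72 h (a higher number here means a weaker inhibitor, a lower number a stronger inhibitor), compound 1 gives 45000 nM. Going by the values given here, compound 3 gives 52500 nM in this assay, a number that lies within the scatter of the one for compound 1. Compound 2 `Cc1nccn1-c1csc(Nc2ccc(Br)cc2)n1` is derived from compound 1 by one change, (hydrogen in place of methyl on an aromatic carbon). Compound 2 reaches only > 100000 nM in this assay, which is a limit and not a number. The step of an at least 2.2-fold higher number from compound 1 to compound 2 (0.34 log units; beyond the scatter) is therefore open at its upper end because of the limit of > 100000 nM in this assay, at which 1 of the 3 values shown sits.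

Compound 4 `COc1ccc(Nc2nc(-n3cnc4ccccc43)cs2)cc1` stands to compound 3 as compound 2 stands to compound 1: hydrogen in place of methyl on an aromatic carbon. The surroundings are not identical. In compound 1 the carbon sits next to the ring nitrogen, two ring bonds from the ring nitrogen, two ring bonds from the ring atom that bears a large group and two ring bonds from the ring atom that bears a methyl group; in compound 3 it sits between two ring nitrogen atoms, next to the ring atom that bears a large group, on a ring that is part of a fused or bridged system of two rings. It is the same kind of change, not the same change.

For compound 4 a step of a 1.8-fold higher number from compound 3 to compound 4 (0.26 log units; within the scatter) in this assay is expected, resting on the measured step of an at least 2.2-fold higher number from compound 1 to compound 2 (0.34 log units; beyond the scatter). Compound 4 is thus estimated at 95000 nM, with a range from 40000 nM to 200000 nM, and with a real chance that the assay reports only a limit.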

Compound 4, half-maximal inhibitory concentration: > 100000 nM
Compound 4 was reported as a limit; the forecaster's own chance of this, stated with the estimate: 50%; at least 1.0-fold (0.02 log units) between middle value and limit.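

In this assay compound 4 gives > 100000 nM, which is a limit and not a number. Read as a step, the loss of the methyl on this second core gives an at least 1.9-fold higher number from compound 3 to compound 4 (0.27 log units; that floor lies within the scatter), so it points the same way as the step on the first core, although its floor alone does not clear the scatter. This shows that the two results are compatible and that neither core keeps a measurable number once the methyl is replaced by hydrogen, but it does not show that the change costs the same on both cores: the same change on two cores in this assay, an at least 2.2-fold higher number (0.34 log units; beyond the scatter) from compound 1 to compound 2 and an at least 1.9-fold higher number (0.27 log units; that floor lies within the scatter) from compound 3 to compound 4; the limit leaves it open whether they differ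

How much weaker compound 2 and compound 4 really are remains open, as the scale of the assay ends where they begin: the limit of > 100000 nM in this assay, at which 2 of the 4 values shown sit. The compounds shown also leave open how a longer chain such as ethyl, or an amine, would read in this assay if it stood in place of the methyl on either core.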